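The compounds below may be only part of what the source reports. "The series", "measured", "known", "first", "only" and "open" are said of these compounds alone.

Compound 1 `Cc1ccc(-c2cc(/N=C3/NC(=O)CS3)cs2)cc1` in a functional assay on HCT-116 cells (Homo sapiens) for cytotoxicity, read by MTT assay, with a stated time of 72 h (on this read-out higher numbers stand for weaker inhibition and lower numbers for stronger inhibition), gives > 50000 nM, which is a limit of the assay rather than a number. Compound 2 `COc1ccc(-c2cc(/N=C3/NC(=O)CS3)cs2)cc1` in this assay also reaches only the limit > 50000 nM. Compound 3 `O=C1CS/C(=N\c2csc(-c3ccc(Cl)cc3)c2)N1` likewise stops at the limit > 50000 nM. Because all three values sit at the limit of > 50000 nM in this assay, at which 3 of the 3 values shown sit, the steps a step that the two limits leave unreadable from compound 1 to compound 2, a step that the two limits leave unreadable from compound 1 to compound 3 and a step that the two limits leave unreadable from compound 2 to compound 3 cannot be read in size or direction. Compound 4 `COc1cccc(N2C(=O)CS/C2=N\c2csc(-c3ccc(C)cc3)c2)c1` differs from compound 1 by 3-methoxyphenyl in place of hydrogen on an amide-type nitrogen in a ring, two ring bonds from the ring sulfur. Going by the values given here, none of the measured steps touches this position, so they give no expected size or direction for this change. Compound 4 is therefore estimated at 40000 nM, between 8000 nM and 100000 nM, which would be an expected step of an at least 1.2-fold lower number from compound 1 to compound 4 (0.09 log units; that floor lies within the scatter).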

Compound 4, half-maximal inhibitory concentration: 41000 nM
For compound 4 the middle estimate is 1.0-fold (0.01 log units) below the measured one, within the range that was stated.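

With 3-methoxyphenyl on the amide-type nitrogen in a ring, compound 4 gives 41000 nM in this assay, a number rather than a limit and the only one among the compounds shown. The change reads as an at least 1.2-fold lower number from compound 1 to compound 4 (0.08 log units; that floor lies within the scatter), so this position allows a measurable value, but a real gain over the parent is not established. The earlier steps remain unreadable: the limit of > 50000 nM in this assay, at which 3 of the 4 values shown sit.

From the compounds shown here alone, whether a plain phenyl, a benzyl or a carboxylic acid on this nitrogen would move the number stays open. So does whether 3-methoxyphenyl gives a measurable value on the cores of compound 2 and compound 3.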